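This account rests on a few compounds, and the source may have more. Where it says the series, first, only, none or still open, it means among the compounds named here.

Measured compounds in a functional assay on NCI-H460 cells (Homo sapiens) for cytotoxicity, read by MTT assay; on this read-out lower numbers stand for stronger inhibition and higher numbers for weaker inhibition:
- compound 1 `COc1cccc(/C=C/C(=O)c2sc(Nc3cccc(C)c3)nc2C)c1` gives > 25000 nM, a limit of the assay and not a number.
- compound 2 `COc1cccc(/C=C/C(=O)c2sc(Nc3ccccc3)nc2C)c1` gives > 25000 nM, likewise a limit.
- compound 3 `Cc1nc(Nc2ccccc2)sc1C(=O)/C=C/c1ccc(Cl)cc1` gives > 25000 nM, again a limit.

Compound 3 thus stands at the limit, as do the two others (the limit of > 25000 nM in this assay, at which 3 of the 3 values shown sit). The step from compound 3 to compound 4 `Cc1ccc(Nc2nc(C)c(C(=O)/C=C/c3ccc(Cl)cc3)s2)cc1` is methyl in place of hydrogen on an aromatic carbon. Among the measured compounds shown here, the one earlier step of the same kind, a step that the two limits leave unreadable from compound 1 to compound 2, is unreadable, as is a step that the two limits leave unreadable from compound 2 to compound 3; neither gives a size. For compound 4 in this assay no step beyond the scatter is expected, a step that the limit leaves unreadable from compound 3 to compound 4, and it is estimated at 40000 nM (range 15000 nM to 120000 nM), most likely reported again as a limit.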

Compound 4, half-maximal inhibitory concentration: > 25000 nM
Compound 4: a limit, no number (the forecaster's own chance of this, stated with the estimate: 85%); the middle value is on the limit's open side.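

Compound 3 and compound 4 each give a limit and not a number, so no new step can be read between them: the limit of > 25000 nM in this assay, at which 4 of the 4 values shown sit.

The compounds shown leave open whether any change on the shared core yields a readable number.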